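The compounds below may be only part of what the source reports. "The series", "measured", "known", "first", "only" and "open" are said of these compounds alone.

Measured compounds:
- compound 1, `COc1cccc(CCC(=O)Nc2nc3ccccc3c(=O)s2)c1`: 367 nM
- compound 2, `O=C(CCCc1ccccc1)Nc1nc2ccc(Cl)cc2c(=O)s1`: > 10000 nM (a limit of the assay, not a number)
- compound 3, `O=C(C/C=C/c1ccc(Cl)c(Cl)c1)Nc1nc2ccccc2c(=O)s1`: >= 1500 nM (a limit of the assay, not a number)

In an assay on membranes from brain for displacement of a labelled ligand from adenosine receptor A1 (Rattus norvegicus), read by scintillation counting, with a stated time of 90 min (a lower number here means a stronger inhibitor, a higher number a weaker inhibitor), compound 2 stands at the limit of > 10000 nM in this assay, at which 1 of the 3 values shown sits, which is a limit of the assay rather than a measured number. Compound 3 likewise sits at the limit of >= 1500 nM in this assay, at which 1 of the 3 values shown sits, also a limit. Among the measured compounds shown here, only compound 1 gives a number in this assay, with 367 nM, and compound 1 carries a different chain and no substituent on its core, so no single-change step among the measured compounds exists.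

Compound 4, `Cc1ccc2nc(NC(=O)CCCc3ccccc3)sc(=O)c2c1`, differs from compound 2 in one place: methyl in place of chloro on an aromatic carbon. With compound 2 known only as a limit, the step from compound 2 to compound 4 in this assay cannot be measured in full; at most a move back into the numbered range could appear. The expected size of the step of an at least 1.4-fold lower number from compound 2 to compound 4 (0.15 log units; that floor lies within the scatter) is therefore uncertain, and a return of another limit is judged about as likely as not. Compound 4 is expected to give 7000 nM, within 1500 nM to 30000 nM.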

Compound 4, inhibition constant: 98.3 nM
The estimate for compound 4 lay 71-fold (1.85 log units) above the measured number; measured number outside the range, below it.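

Exchanging chloro for methyl on this aromatic carbon gives, in this assay, an at least 100-fold lower number from compound 2 to compound 4 (2.00 log units; beyond the scatter), although only one heavy atom leaves and one enters, and no ring, hydrogen-bond donor or hydrogen-bond acceptor changes. The earlier compounds offered no single-change step, so this is the only view shown of this position with the chain held the same, and it shows that the choice of group here can decide the result in this assay. The value of compound 2 is a limit of the assay, not a number, so the size of the step is only a floor: the limit of > 10000 nM in this assay, at which 1 of the 4 values shown sits.

From the compounds shown here alone, it stays open whether a hydrogen, a fluoro or a methoxy on this carbon would fall nearer compound 4 or compound 2. Going by these compounds, it also stays open whether methyl here would give a step of like size with the chain of compound 1 or of compound 3.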